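The compounds below may be only part of what the source reports. "The series", "measured", "known", "first", "only" and "open" are said of these compounds alone.

Measured in an ADME assay on microsomes from liver (Mus musculus) for metabolic stability, using NADPH, with a stated time of 60 min, in the presence of a further agent that is not named here; a lower number here means slower removal, a higher number faster removal of the compound:

- compound 1 `CC(=O)NC1C2CC3CC1CC(C2)C31OO[C@]2(CC[C@@H](c3ccc(OCC(=O)O)cc3)CC2)O1`: < 7 mL.min-1.g-1
- compound 2 `O=C(O)COc1ccc([C@H]2CC[C@]3(CC2)OOC2(O3)C3CC4CC(C3)CC2C4)cc1Cl`: 8 mL.min-1.g-1

The entry for compound 1 is < 7 mL.min-1.g-1, which is a limit of the assay and not a number. Going by the values given here, compound 2 gives the only actual number so far, 8 mL.min-1.g-1, so it is the sole firm reference point in this assay.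

The next compound, compound 3 `O=C(O)COc1ccc([C@H]2CC[C@]3(CC2)OOC2(O3)C3CC4CC(C3)CC2C4)cc1C(=O)O`, keeps the core of compound 2 and carries a carboxy in place of chloro on an aromatic carbon, ortho to a carboxymethoxy group: carboxy in place of chloro on an aromatic carbon. Among the compounds with values here, no measured pair here differs in one place only, so nothing yet shows the size of such a change. The expectation is a small fall in this assay, or none beyond the scatter. The expected change is a 1.6-fold lower number from compound 2 to compound 3 (0.20 log units; within the scatter). For compound 3 the estimate is 5 mL.min-1.g-1, with an expected range from 2 mL.min-1.g-1 to 9 mL.min-1.g-1.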

Compound 3, intrinsic clearance in microsomes: 8 mL.min-1.g-1
Estimate against measurement, compound 3: 1.6-fold (0.20 log units) below; measured number inside the range.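

Going by these compounds alone, on the aromatic carbon ortho to a carboxymethoxy group, carboxy in place of chloro gives the only step in this assay between compounds that differ in one place, and it reads no change at the digits printed from compound 2 to compound 3 (within the scatter). At this position, then, a single chlorine can give way to a carboxy, with its hydrogen-bond donor and hydrogen-bond acceptor, and intrinsic clearance in microsomes shows no step beyond the scatter. A fall would have had little room to show in this read-out: the limit of < 7 mL.min-1.g-1 in this assay, at which 1 of the 3 values shown sits.

Going by these compounds, whether an amine or a methyl ester at this same position would also leave the read-out in place stays open. So does whether the same exchange would read alike on the core of compound 1, whose entry of < 7 mL.min-1.g-1 is a limit of the assay and not a number.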